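The source may hold more compounds than are shown below. What is called first, only, known or untested is meant among the compounds shown, and "the series" means these compounds.

Working notes on the urea series.

Going by the values given here, compound 1 `COc1cc(NC(=O)Nc2cc(Nc3ccc(C(C)(C)C)cc3)ncn2)cc(OC)c1` sits at the bottom of the three numbers measured so far: in a functional assay on NCI-H1581 cells (Homo sapiens) for inhibition, read by MTT assay, with a stated time of 48 h, tested at 10 uM (on this read-out lower numbers stand for less inhibition and higher numbers for more inhibition at the one concentration tested (going by the name of the read-out)), compound 1 gives 38.7%. Among the compounds with values here, compound 2 `COc1ccc(F)cc1Nc1cc(NC(=O)Nc2c(Cl)cccc2Cl)ncn1` gives 73.1% and compound 3 `Cc1ccc(Nc2cc(NC(=O)Nc3c(Cl)cccc3Cl)ncn2)cc1C` gives 73.3%; both stand well above compound 1, but no single-point step links either of them to compound 1, since they carry a different aryl on the urea, so only the raw values can be set side by side.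

Compound 4 `COc1cc(NC(=O)Nc2cc(Nc3ccc(C)c(C)c3)ncn2)cc(OC)c1` differs from compound 1 in one place: 3,4-dimethylphenyl in place of 4-(tert-butyl)phenyl on a nitrogen on an aromatic ring.

Within the data shown here, the one measured step that bears on this position is the swap on the same nitrogen between compound 2 and compound 3, which gave a number 0.2 percentage points higher from compound 2 to compound 3 (within the scatter). That step brought in the same 3,4-dimethylphenyl group that enters here, though from a different starting aryl, and it left the read-out essentially where it was. On that basis no step beyond the scatter is expected for the change from compound 1 to compound 4, and the expected step is a number 3.3 percentage points higher from compound 1 to compound 4 (within the scatter).

Compound 4 is therefore estimated at 42%, with a range from 25% to 60%.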

Compound 4, a percentage reported as inhibition, at one concentration (the size of the read-out at that concentration, not a potency): 20.1%
Beside the measured number, compound 4's estimate is 21.9 percentage points above it; measured number outside the range, below it.
By their numbers in this assay, from the lowest: compound 4; then compound 1; then compounds 2 and 3 (each within the scatter of the next).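

On the nitrogen on an aromatic ring, the exchange of 4-(tert-butyl)phenyl for 3,4-dimethylphenyl is not neutral in this series: in this assay it gives a number 18.6 percentage points lower from compound 1 to compound 4 (beyond the scatter) and so lies beyond the scatter, while the earlier change on the same nitrogen gave a number 0.2 percentage points higher from compound 2 to compound 3 (within the scatter) and stayed within it. The same entering group therefore goes with a flat step in one pair and a downward step in the other, so a flat step in one pair does not carry over to a pair with a different aryl on the urea and a different group leaving. Nothing available on these compounds accounts for the drop.

The two steps differ in both the leaving group and the aryl on the urea, so the compounds shown cannot separate whether the size of the step follows the departing 4-(tert-butyl)phenyl or the urea partner. From the compounds shown here alone, how a plain phenyl, or a phenyl carrying a morpholine or a carboxylic acid, would read on this nitrogen remains open, as does the effect of 4-(tert-butyl)phenyl alongside the dichlorinated urea aryl of compound 2 and compound 3.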